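This account rests on a few compounds, and the source may have more. Where it says the series, first, only, none or still open, it means among the compounds named here.

In a functional assay on A549 cells (Homo sapiens) for antiproliferative activity, read by MTT assay, with a stated time of 72 h (on this read-out higher numbers stand for weaker inhibition and lower numbers for stronger inhibition), compound 1 (`COc1cc(-c2ncnn2-c2cccc(F)c2)cc(OC)c1OC`) gives > 10000 nM, which is a limit and not a number. Compound 1 therefore stands at the limit of > 10000 nM in this assay, at which 1 of the 2 values shown sits. Compound 2 (`COc1cc(-n2ncnc2-c2ccc(C)cc2)cc(OC)c1OC`) gives a number in this assay, 1100 nM. Within the data shown here, no two measured compounds differ in one place, so the series shows no measured step that could size a change on the shared core.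

Compound 3 (`COc1cc(-c2ncnn2-c2ccc(Cl)cc2Cl)cc(OC)c1OC`) carries 2,4-dichlorophenyl in place of 3-fluorophenyl on an aromatic nitrogen of a five-membered aromatic ring with 3 nitrogen: 2,4-dichlorophenyl in place of 3-fluorophenyl on an aromatic nitrogen. Among the measured compounds shown here, with no measured step to go on, the expectation starts from compound 1 and its limit of > 10000 nM. No change beyond the scatter is expected in this assay, in either direction, and a further reading at the limit would be no surprise. The estimated change is a number no higher from compound 1 to compound 3 (the limit leaves the size open). For compound 3 the estimated value is 10000 nM, with an expected range of 2500 nM to 30000 nM.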

Compound 3, half-maximal inhibitory concentration: > 10000 nM
Compound 3 gave a limit, no number; the forecaster's own chance of this, stated with the estimate: 55%; the middle value sits exactly at the limit.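

Compound 1 and compound 3 both stop at a limit in this assay, so 2,4-dichlorophenyl in place of 3-fluorophenyl gives no readable step: the limit of > 10000 nM in this assay, at which 2 of the 3 values shown sit.

The compounds shown leave open whether this change on the aromatic nitrogen alters activity at all in this assay, and how far either compound lies from a measurable value.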